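Lengthening the ether chain and adding a dipropylamino group

The source may report more compounds than this note shows. Statements on the series, on what has been measured and on what is new or still open speak of the compounds shown alone.

Compound 1 `CCCOc1c(-c2cc(OC)c(OC)c(OC)c2)oc2ccccc2c1=O` and compound 2 `CCCCCCCOc1c(-c2cc(OC)c(OC)c(OC)c2)oc2ccccc2c1=O` share one core and differ only in the chain attached to the ring oxygen. In a functional assay on LNCaP cells (Homo sapiens) for antiproliferative activity, read by WST assay, with a stated time of 3 days (a higher number here means a weaker inhibitor, a lower number a stronger inhibitor), compound 1 gives 5700 nM. For compound 2 the assay reports only a limit, > 50000 nM. The measured step of an at least 8.7-fold higher number from compound 1 to compound 2 (0.94 log units; beyond the scatter) thus shows that the longer chain weakens inhibition, and compound 2 stands at the limit of > 50000 nM in this assay, at which 1 of the 2 values shown sits, rather than at a definite number.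

Compound 3 `CCCN(CCC)CCCCCOc1c(-c2cc(OC)c(OC)c(OC)c2)oc2ccccc2c1=O` carries the change (dipropylamino in place of ethyl on a saturated chain carbon, five bonds along the chain from an oxygen on an aromatic ring). Going by the values given here, no measured step covers this change directly; the only step seen, an at least 8.7-fold higher number from compound 1 to compound 2 (0.94 log units; beyond the scatter), concerns chain length alone and points toward weaker inhibition as the chain grows, and compound 3 keeps a long chain. As far as these compounds go, because compound 2 sits at the limit of > 50000 nM in this assay, at which 1 of the 2 values shown sits, the true starting point of the step is unknown and any direction is possible. Compound 3 is expected to give about 20000 nM in this assay, with a plausible range from 4000 nM to 60000 nM. That estimate implies an expected step of an at least 2.5-fold lower number from compound 2 to compound 3 (0.39 log units; beyond the scatter), held with low confidence.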

Compound 3, half-maximal inhibitory concentration: 7600 nM
Estimate against measurement, compound 3: 2.6-fold (0.42 log units) above; measured number inside the range.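

Dipropylamino in place of ethyl, on a saturated chain carbon, five bonds along the chain from an oxygen on an aromatic ring, gives an at least 6.5-fold lower number from compound 2 to compound 3 (0.81 log units; beyond the scatter) in this assay. Set against the short propyl chain, the long chain carrying this group shows a 1.3-fold higher number from compound 1 to compound 3 (0.12 log units; within the scatter), so among these three compounds chain length alone does not decide the result, and a long chain can keep the activity of the short one when it ends in dipropylamino. The first of these steps gives only a minimum size, because compound 2 has a limit rather than a definite number: the limit of > 50000 nM in this assay, at which 1 of the 3 values shown sits.

The compounds shown leave open whether this effect belongs to dipropylamino in particular or would also appear with a smaller amine such as dimethylamino, or with a carboxylic acid in the same place. As far as these compounds go, they also leave open how the activity would shift if dipropylamino sat on a shorter or a longer chain, so the best distance from the ring oxygen remains unknown.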